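The compounds below may be only part of what the source reports. "The series", "measured", "known", "first", "only" and "open" are said of these compounds alone.

Of the compounds shown here, three have been measured in an assay on COS-7 cells for inhibition of patatin-like phospholipase domain-containing protein 2 (Mus musculus); a higher number here means a weaker inhibitor, a lower number a stronger inhibitor. Compound 1 `CCOC(=O)c1cc(-c2ccc(OCC)cc2)ccn1` gives 105000 nM. Compound 2 `CCOC(=O)c1cccc(-c2ccc(OCC)cc2)c1`, which carries the same ester and the same aryl group on a different core, gives 50000 nM in this assay. Compound 3 `CCOC(=O)c1cccc(-c2ccc([N+](=O)[O-])cc2)c1` gives 95000 nM in this assay. Among the measured compounds shown here, the only pair that differs in a single place is compound 2 and compound 3, and that step, a 1.9-fold higher number from compound 2 to compound 3 (0.28 log units; within the scatter), is nitro in place of ethoxy on an aromatic carbon. On these three numbers compound 3 stands second highest; its nearest neighbour is compound 1 and its furthest is compound 2, and both gaps lie within the scatter.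

Compound 4 `CCOC(=O)c1cccc(-c2ccc(CN3CCCCC3)cc2)c1` is not yet measured. It differs from compound 3 in one place: (piperidin-1-yl)methyl in place of nitro on an aromatic carbon. For the measured compounds named here, no measured step bears on this change. Going by the values given here, the single known step at that carbon, ethoxy to nitro, stayed within the scatter, and no compound carries a ring-bearing substituent at that place. With all three known numbers in a narrow band, the expected step of a 1.2-fold lower number from compound 3 to compound 4 (0.07 log units; within the scatter) is none beyond the scatter. Compound 4 is therefore estimated at 80000 nM, with a range from 25000 nM to 250000 nM.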

Compound 4, half-maximal inhibitory concentration: 75000 nM
Compound 4: the middle estimate sits 1.1-fold (0.03 log units) above what was measured; low and high end bracket the measured number.
By their numbers in this assay, from the lowest: compounds 2, 4, 3 and 1 (each within the scatter of the next, the first and the last beyond it).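

At this aromatic carbon, para to a large group, (piperidin-1-yl)methyl in place of nitro gives a 1.3-fold lower number from compound 3 to compound 4 (0.10 log units; within the scatter) in this assay, and in place of ethoxy it gives a 1.5-fold higher number from compound 2 to compound 4 (0.18 log units; within the scatter) on the same core. Among the compounds shown here, the earlier compounds covered only the step between ethoxy and nitro, whereas ethoxy, nitro and a substituent with a six-membered non-aromatic ring now all stand within the scatter of one another at this place, so neither the ring nor the added size of the group produces a step that can be read beyond it. No measurement at hand offers an explanation for this flat picture.

The compounds shown leave open whether any group at this carbon can move the number beyond the scatter, and a carboxylic acid, a primary amine or a longer alkyl chain would be informative tests. Also open is whether the same tolerance holds on the core of compound 1, which is shown only with ethoxy, and what replacing the ethyl ester with an amide would do on either core.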